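The source may hold more compounds than are shown below. What is called first, only, known or untested is meant among the compounds shown, and "the series" means these compounds.

Compound 1 `O=C(COc1ccc2cc(/C=C3/SC(=O)NC3=O)ccc2c1)Nc1ccc(Br)cc1F`: 1900 nM
Compound 2 `O=C(COc1ccc2cc(/C=C3/SC(=O)NC3=O)ccc2c1)Nc1ccccn1`: 17000 nM

In an assay on isolated protein for inhibition of histone deacetylase 4 (Homo sapiens), with a stated time of 1 h (on this read-out higher numbers stand for weaker inhibition and lower numbers for stronger inhibition), compound 1 stands lowest of the two numbers measured; its nearest neighbour is compound 2, at 17000 nM. Compound 3 `O=C(COc1ccc2cc(/C=C3/SC(=O)NC3=O)ccc2c1)Nc1ccc(F)cc1` differs from compound 1 in one place: 4-fluorophenyl in place of 4-bromo-2-fluorophenyl on an amide-type nitrogen. Among the measured compounds shown here, the only measured step, an 8.9-fold higher number from compound 1 to compound 2 (0.95 log units; beyond the scatter), concerns a different replacement on the same amide-type nitrogen, so it bears on this change only loosely. Since compound 3 keeps an aryl group there, a smaller shift toward a higher number is expected, a 1.8-fold higher number from compound 1 to compound 3 (0.27 log units; within the scatter). Compound 3 is therefore estimated at 3500 nM, within 1200 nM to 10000 nM.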

Compound 3, half-maximal inhibitory concentration: 1600 nM
Estimate against measurement, compound 3: 2.2-fold (0.34 log units) above; measured number inside the range.
By their numbers in this assay, from the lowest: compounds 3 and 1 (each within the scatter of the next); then compound 2.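

In this assay, 4-bromo-2-fluorophenyl and 4-fluorophenyl on the amide-type nitrogen cannot be told apart (a 1.2-fold lower number from compound 1 to compound 3 (0.07 log units; within the scatter)), so the bromine and the second fluorine are not needed for this level of inhibition. The gap to pyridin-2-yl holds with the simpler ring as well (an 11-fold lower number from compound 2 to compound 3 (1.03 log units; beyond the scatter)), and thus does not depend on the bromine. Nothing given here explains these differences. The compounds shown leave open whether unsubstituted phenyl would match 4-fluorophenyl. They also leave open how an amine or a carboxylic acid on that ring would fare.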